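The source may report more compounds than this note shows. Statements on the series, on what has been measured and on what is new or still open speak of the compounds shown alone.

Within the data shown here, compound 2 `COc1cc2c(Oc3ccc(NC(=O)c4nccc(-c5ccc(F)cc5)n4)cc3F)ccnc2cc1OCCCN1CCN(C)CC1` is the only member of this small set with a number in a functional assay on A549 cells (Homo sapiens) for cytotoxicity, read by MTT assay, with a stated time of 72 h (a higher number here means a weaker inhibitor, a lower number a stronger inhibitor), where compound 2 gives 680 nM. Its companion compound 1 `COc1cc2c(Oc3ccc(NC(=O)c4nccc(-c5ccc(C)cc5)n4)cc3F)ccnc2cc1OCCCN1CCN(C)CC1` shows "not determined" (no result reported) in this assay, so no comparison between the two can be drawn. Compound 3 `COc1cc2c(Oc3ccc(NC(=O)c4nccc(-c5ccc(F)cc5F)n4)cc3F)ccnc2cc1OCCCN1CCN(C)CC1` differs from compound 2 by fluoro in place of hydrogen on an aromatic carbon, which is fluoro in place of hydrogen on an aromatic carbon. Among the measured compounds shown here, with no measured step to lean on, the change is expected to move this assay little, by about a 1.1-fold lower number from compound 2 to compound 3 (0.05 log units; within the scatter) and not beyond the usual scatter. Compound 3 is therefore estimated at 600 nM, within 250 nM to 1500 nM.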

Compound 3, half-maximal inhibitory concentration: 660 nM
Estimate against measurement, compound 3: 1.1-fold (0.04 log units) below; the range from low to high includes it.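

Going from 4-fluorophenyl to 2,4-difluorophenyl, with fluoro in place of hydrogen on an aromatic carbon ortho to a large group, gives a 1.0-fold lower number from compound 2 to compound 3 (0.01 log units; within the scatter) in this assay. Among these compounds, this is the first measured step in the set, and it shows that this position can carry a fluoro group with the number staying within the scatter. No supporting data bear on the reason for this result. The compounds shown leave open how a chloro group, a methoxy group or an amine at this same position would read in this assay.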